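Swapping an Amino Linker for a Sulfonyl Ester

The source may hold more compounds than are shown below. What is called first, only, known or untested is meant among the compounds shown, and "the series" means these compounds.

Of the compounds shown here, three share one core and have been tested in a functional assay on MDA-MB-435 cells (Homo sapiens) for cytotoxicity, read by MTT assay, with a stated time of 72 h; on this read-out lower numbers stand for stronger inhibition and higher numbers for weaker inhibition. Compound 1 `N[C@H]1CC[C@H](Nc2c(C(=O)NCc3ccc(Oc4ccccc4)cc3)nc(Br)c3cccnc23)CC1` gives 4000 nM in this assay. Compound 3 `N[C@H]1CC[C@H](Nc2c(C(=O)NCc3cccs3)nc(Br)c3cccnc23)CC1` gives 4100 nM. Compound 2 `COC(=O)CNc1c(C(=O)NCc2ccc(F)cc2)nc(Br)c2cccnc12` gives 10000 nM, the highest of the three numbers; its nearest neighbour is compound 3 and its furthest is compound 1, and both of those gaps lie beyond the scatter, so compound 2 is the weakest of the set.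

Compound 4 `Cc1ccc(S(=O)(=O)Oc2c(C(=O)NCc3ccc(F)cc3)nc(Br)c3cccnc23)cc1` keeps the core of compound 2 and changes one group on an aromatic carbon: ((4-methylphenyl)sulfonyl)oxy in place of ((methoxycarbonyl)methyl)amino on an aromatic carbon. The incoming group has no hydrogen-bond donor and carries an extra aromatic ring.

Within the data shown here, no measured pair shows this kind of change, so nothing here says how large a step it brings. A small step in either direction, possibly none beyond the scatter, seems the fairest expectation, so compound 4 is estimated at 9000 nM, with a range from 2500 nM to 30000 nM. That estimate corresponds to an expected step of a 1.1-fold lower number from compound 2 to compound 4 (0.05 log units; within the scatter).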

Compound 4, half-maximal inhibitory concentration: > 20000 nM
Compound 4: a limit, no number; the forecaster's own chance of this, stated with the estimate: 25%; middle value at least 2.2-fold (0.34 log units) from the limit.
By their numbers in this assay, from the lowest: compounds 1 and 3 (each within the scatter of the next); then compound 2. At a limit, above all of these: compound 4.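

Compound 4 gives no number here, only a limit of the assay: the limit of > 20000 nM in this assay, at which 1 of the 4 values shown sits. Placing ((4-methylphenyl)sulfonyl)oxy on this aromatic carbon, para to the bromo group, in place of ((methoxycarbonyl)methyl)amino gives an at least 2.0-fold higher number from compound 2 to compound 4 (0.30 log units; that floor lies within the scatter), so the change brings no gain on this read-out, and the true size of the step stays unknown, with its floor within the scatter. The earlier compounds shown here all carried an amino-linked group at this position, and compound 4 now shows that a group joined through oxygen, with no hydrogen-bond donor and an extra aromatic ring, does not lower the number.

These compounds cannot separate the loss of the donor from the gain of the ring. A methylamino or a methoxy group on this carbon, with the rest of compound 2 kept, would help to tell them apart.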